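Returning from methoxyphenyl to a methylphenyl chain end

The source may hold more compounds than are shown below. What is called first, only, known or untested is meant among the compounds shown, and "the series" means these compounds.

Compound 2 `CCn1nc(C)c2c1CCN(C(C(=O)NC)c1ccccc1)C2CCc1ccc(OC)cc1` and compound 1 `CCn1nc(C)c2c1CCN(C(C(=O)NC)c1ccccc1)C2CCc1cccc(C(F)(F)F)c1` share one core and differ only at the end of the two-carbon chain. In a functional assay on CHO cells for antagonist activity at Orexin receptor type 2 (Homo sapiens), read by FLIPR and calcium flux (on this read-out lower numbers stand for stronger inhibition and higher numbers for weaker inhibition), compound 1 gives 7 nM, while compound 2 gives 219 nM. That change was a 31-fold higher number from compound 1 to compound 2 (1.50 log units; beyond the scatter), so compound 2 stands with the highest number of the two, and its nearest neighbour is compound 1.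

Compound 3 `CCn1nc(C)c2c1CCN(C(C(=O)NC)c1ccccc1)C2CCc1cccc(C)c1` is the next step: 3-methylphenyl in place of 4-methoxyphenyl on a saturated chain carbon, two bonds along the chain from a saturated ring carbon. Among the measured compounds shown here, no measured step covers exactly this change. For the measured compounds named here, the only step that bears on it is a 31-fold higher number from compound 1 to compound 2 (1.50 log units; beyond the scatter), which ran in the opposite direction when the 3-(trifluoromethyl)phenyl of compound 1 gave way to the 4-methoxyphenyl of compound 2. Since compound 3 removes that 4-methoxyphenyl again and puts a 3-methylphenyl in its place, he expects the number in this assay to fall part of the way back toward compound 1, though not necessarily all of it. He therefore estimates an 11-fold lower number from compound 2 to compound 3 (1.04 log units; beyond the scatter) for compound 3, giving an expected value of 20 nM with a range from 5 nM to 80 nM.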

Compound 3, half-maximal inhibitory concentration: 19 nM
For compound 3 the middle estimate is 1.1-fold (0.02 log units) above the measured one; measured number inside the range.
By their numbers in this assay, from the lowest: compound 1; then compound 3; then compound 2.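

In this assay a 3-methylphenyl at the end of the chain brings back most of what the 4-methoxyphenyl had cost, with a 12-fold lower number from compound 2 to compound 3 (1.06 log units; beyond the scatter) standing as a large step in its own right. Among the compounds shown here, the low numbers are therefore not tied to trifluoromethyl alone: the comparison that changes only that group, methyl in place of trifluoromethyl on an aromatic carbon, gives a 2.7-fold higher number from compound 1 to compound 3 (0.43 log units; beyond the scatter) and this modest step, though beyond the scatter, is far smaller than the step to compound 2. Nothing in hand explains why either change moves the number as it does.

The step to compound 3 changes both the group and its place on the ring at once, so the compounds shown leave open whether the high number of compound 2 belongs to the methoxy group or to its place; a 3-methoxyphenyl or a 4-methylphenyl chain end would separate the two. Also open, going by these compounds, is how a plain phenyl or a 3-chlorophenyl at the chain end would compare with the methyl and trifluoromethyl compounds.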